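Urea series, cytotoxicity on A549: trifluoromethyl step from compound 1

The source may hold more compounds than are shown below. What is called first, only, known or untested is meant among the compounds shown, and "the series" means these compounds.

Among the compounds with values here, the two measured members share a common core. Compound 1 is `C=CCSc1nsc(NC(=O)Nc2ccc(Cl)cc2)n1` and compound 2 is `C=CCSc1nsc(NC(=O)Nc2ccc(F)cc2F)n1`. In an ADME assay on A549 cells (Homo sapiens) for cytotoxicity, read by MTT assay, tested at 100 uM (on this read-out higher numbers stand for a weaker effect at the one concentration tested and lower numbers for a stronger effect), compound 1 gives 15.1%, and in this assay compound 2 gives 31.3%. Compound 1 therefore stands at the lowest of the two numbers, with compound 2 the nearest neighbour and a number higher by a gap beyond the usual scatter, so compound 1 shows the stronger effect of the pair at the one concentration tested.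

Compound 3, `C=CCSc1nsc(NC(=O)Nc2ccc(Cl)cc2C(F)(F)F)n1`, differs from compound 1 in one place: trifluoromethyl in place of hydrogen on an aromatic carbon. The chloro group of compound 1 stays where it is.

Within the data shown here, no step between measured compounds covers this change, so the expected size rests only on the position of compound 1 in this assay. A modest step upward, weaker effect, is expected, and one that may stay within the scatter: a number 7.9 percentage points higher from compound 1 to compound 3 (within the scatter). For compound 3 the expected value in this assay is 23%, estimated between 9% and 45%, because compound 1 sits at 15.1% and the remaining number in the series, compound 2 at 31.3%, shows how far a single change on this ring has moved the read-out so far.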

Compound 3, a percentage reported as activity, at one concentration (the size of the read-out at that concentration, not a potency): 43.1%
Beside the measured number, compound 3's estimate is 20.1 percentage points below it; the measured number falls inside the stated range.
By their numbers in this assay, from the lowest: compound 1; then compound 2; then compound 3.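

In this assay, trifluoromethyl in place of hydrogen on an aromatic carbon, ortho to a large group and meta to a chloro group, gives a number 28 percentage points higher from compound 1 to compound 3 (beyond the scatter). This shows that the read-out responds to a change at this position, with the chloro group held in place, and that the response runs towards a weaker effect at the one concentration tested; the two earlier compounds differ in more than one place, so they could not tie any shift to a single position. Nothing available here bears on why the read-out moves with this change.

A single step at a single position leaves open whether the shift belongs to trifluoromethyl itself or would appear with other groups at this carbon, such as a methyl group, a methoxy group, an amine or a carboxylic acid. It also leaves open whether trifluoromethyl would give a step of similar size on a ring without the chloro group, or with another halogen in its place.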